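The source may report more compounds than this note shows. Statements on the series, on what has been measured and on what is new or still open speak of the compounds shown alone.

Measured so far:
- compound 1, `NC(=O)c1c(NC(=O)c2cccc([N+](=O)[O-])c2)sc2c1CCN(Cc1ccc(Cl)cc1Cl)C2`: 16500 nM in a functional assay on MKN-74 cells (Homo sapiens) for antiproliferative activity, with a stated time of 24 h; a lower number here means a stronger inhibitor, a higher number a weaker inhibitor
- compound 2, `NC(=O)c1c(NC(=O)c2ccc(C(F)(F)F)cc2)sc2c1CCN(C(=O)Nc1ccccc1Cl)C2`: 43900 nM in this assay

Compound 2 stands as the highest of the two numbers in this assay; its nearest neighbour is compound 1, whose number is lower by a margin beyond the scatter of repeated measurements. Going by the values given here, these two compounds differ in more than one place, so their pair shows only that a lower number and a higher number are both reached within this small set.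

Compound 3, `NC(=O)c1c(NC(=O)c2cccc([N+](=O)[O-])c2)sc2c1CCN(C(=O)Nc1ccccc1Cl)C2`, follows from compound 2 by one change: 3-nitrophenyl in place of 4-(trifluoromethyl)phenyl on a carbonyl carbon. No step between measured compounds isolates this change, so the expected size rests only on the numbers shown. Compound 1 carries the same 3-nitrophenyl group and gives a lower number than compound 2, so a mild move toward a lower number, within or at the edge of the scatter, is expected. Compound 3 is therefore estimated at 30000 nM, a step of a 1.5-fold lower number from compound 2 to compound 3 (0.17 log units; within the scatter), with a range from 10000 nM to 90000 nM.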

Compound 3, half-maximal inhibitory concentration: 22700 nM
Beside the measured number, compound 3's estimate is 1.3-fold (0.12 log units) above it; the measured number falls inside the stated range.
By their numbers in this assay, from the lowest: compounds 1, 3 and 2 (each within the scatter of the next, the first and the last beyond it).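

In this assay the exchange of 4-(trifluoromethyl)phenyl for 3-nitrophenyl on a carbonyl carbon gives a 1.9-fold lower number from compound 2 to compound 3 (0.29 log units; within the scatter) and so, with the (2-chlorophenyl)carbamoyl group held fixed, does not move the number beyond the scatter. With 3-nitrophenyl held fixed, (2-chlorophenyl)carbamoyl in place of 2,4-dichlorobenzyl on an amine nitrogen in a ring gives a 1.4-fold higher number from compound 1 to compound 3 (0.14 log units; within the scatter) and so leaves these two groups indistinguishable in this small set. No supporting measurement is available to explain either step.

The compounds shown leave open whether a phenyl ring carrying an amine or a carboxylic acid on that carbonyl carbon would give a number beyond the scatter. They also leave open what a simple alkyl chain, such as butyl, would give on the amine nitrogen in a ring.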